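The source may report more compounds than this note shows. Statements on the series, on what has been measured and on what is new or still open speak of the compounds shown alone.

Compound 1 `Cc1nn(-c2ccccc2I)c2c1C(c1ccc(Oc3ccccc3)cc1)SC(C)C(=O)N2` reaches the higher of the two efficacies recorded here, and in an assay on isolated protein for agonist activity at Bile acid receptor (Homo sapiens), read by AlphaScreen, with a stated time of 30 min (on this read-out higher numbers stand for larger maximal responses and lower numbers for smaller maximal responses), compound 1 gives 130%. Compound 2 `Cc1ccccc1-n1nc(C)c2c1NC(=O)[C@H](C)S[C@@H]2c1ccc(-c2ccco2)cc1` is the nearest point of comparison: in this assay compound 2 gives 32%, a gap well beyond the usual scatter. Compound 3 `Cc1nn(-c2ccccc2Br)c2c1C(c1ccc(Oc3ccccc3)cc1)SC(C)C(=O)N2` is related to compound 1 by a single change, (bromo in place of iodo on an aromatic carbon). Going by the values given here, no measured pair isolates this exchange of bromo for iodo, so nothing beyond the scatter is anticipated. The expected shift is a number 10 percentage points lower from compound 1 to compound 3 (within the scatter). Compound 3 is therefore estimated at 120% in this assay, between 85% and 150%.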

Compound 3, largest response reached (reported as efficacy), in percent of the reference or control that the assay uses: 84%
Compound 3: middle estimate off by 36 percentage points, on the high side; measured number outside the range, below it.
By their numbers in this assay, from the lowest: compound 2; then compound 3; then compound 1.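

In this assay, the exchange of iodo for bromo on an aromatic carbon, ortho to a large group, reads as a number 46 percentage points lower from compound 1 to compound 3 (beyond the scatter). This place on the shared core is therefore not indifferent to the halogen it carries, although one heavy atom simply replaces another, with no donor, acceptor or charge involved. No measurement given here accounts for the size of this step. From the compounds shown here alone, whether chloro, fluoro or methoxy at this place would give a number nearer compound 1 or compound 3 remains open. So does whether the step would persist on a core bearing furan-2-yl, as compound 2 does.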